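The source may report more compounds than this note shows. Statements on the series, on what has been measured and on what is new or still open speak of the compounds shown alone.

In a functional assay on MCF7 cells (Homo sapiens) for cytotoxicity (on this read-out higher numbers stand for weaker inhibition and lower numbers for stronger inhibition), compound 1 (`C=C/C=C\[C@H](C)[C@H](OC(N)=O)[C@@H](C)[C@H](O)[C@@H](C)C/C(C)=C\[C@H](C)[C@@H](O)[C@@H](C)/C=C\CCc1sccc1C`) gives 620 nM and compound 2 (`C=C/C=C\[C@H](C)[C@H](OC(N)=O)[C@@H](C)[C@H](O)[C@@H](C)C/C(C)=C\[C@H](C)[C@@H](O)[C@@H](C)/C=C\CCc1ccsc1`) gives 4000 nM as the higher of the two numbers. Compound 3 (`C=C/C=C\[C@H](C)[C@H](OC(N)=O)[C@@H](C)[C@H](O)[C@@H](C)C/C(C)=C\[C@H](C)[C@@H](O)[C@@H](C)/C=C\CCc1cccc(O)c1`) differs from compound 2 at the same chain place (3-hydroxyphenyl in place of thiophen-3-yl on a saturated chain carbon, two bonds along the chain from a double-bonded chain carbon). For the measured compounds named here, the only measured step bearing on this is a 6.5-fold higher number from compound 1 to compound 2 (0.81 log units; beyond the scatter) at that place, and no measured compound carries a 3-hydroxyphenyl there. A smaller step toward a lower number is therefore expected, with the direction uncertain. The estimated change is a 2.7-fold lower number from compound 2 to compound 3 (0.43 log units; beyond the scatter) in this expectation. For compound 3 the estimated value is 1500 nM with an expected range from 300 nM to 6000 nM in this read-out.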

Compound 3, half-maximal inhibitory concentration: 390 nM
Beside the measured number, compound 3's estimate is 3.8-fold (0.59 log units) above it; the measured number falls inside the stated range.
By their numbers in this assay, from the lowest: compounds 3 and 1 (each within the scatter of the next); then compound 2.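

In this assay, the 3-hydroxyphenyl group gives a 10-fold lower number from compound 2 to compound 3 (1.01 log units; beyond the scatter) at this chain place, so the response there is not confined to a change between thiophenes. Set against 3-methylthiophen-2-yl, the same group gives a 1.6-fold lower number from compound 1 to compound 3 (0.20 log units; within the scatter) and stays within the scatter, which leaves compound 2, with thiophen-3-yl, as the weakest of the three. Nothing measured here accounts for these differences.

It remains open whether the hydroxyl group contributes to the result, since neither plain phenyl nor 3-methoxyphenyl appears in the compounds shown. From the compounds shown here alone, the effect of a 3-aminophenyl group or a longer chain before the ring also remains unknown.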